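A few compounds are considered here, and "the series" means these few. Any claim that something is new, unique, unknown or untested is made for them only; others in the source may bear on it.

Compound 2, `C=CCn1c(=O)/c(=C\c2cccc(Br)c2)[nH]c(=O)/c1=C\c1ccccc1OC`, stands at the lowest number among the two that were reported with a value in a functional assay on U-937 cells (Homo sapiens) for cytotoxicity, read by CCK-8 assay, with a stated time of 72 h (a lower number here means a stronger inhibitor, a higher number a weaker inhibitor), where compound 2 gives 1100 nM; its nearest neighbour is compound 1, `C=CCn1c(=O)/c(=C\c2cccc(Cl)c2)[nH]c(=O)/c1=C\c1ccccc1OC`, which in this assay gives 1200 nM, and the two lie within the scatter. Among the measured compounds shown here, the single measured step, a 1.1-fold lower number from compound 1 to compound 2 (0.04 log units; within the scatter), shows that bromo in place of chloro on an aromatic carbon changes nothing beyond the scatter. Compound 3, `C=CCn1c(=O)/c(=C\c2cccc(Br)c2)[nH]c(=O)/c1=C\c1cccc(Br)c1`, was reported in this assay only as "not active" (no number reported), without a number; its two values with compound 2 show that exchanging the 2-methoxyphenyl side for a second 3-bromophenyl removes the measurable effect.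

Compound 4, `C=CCn1c(=O)/c(=C\c2ccccc2F)[nH]c(=O)/c1=C\c1ccccc1OC`, differs from compound 2 in one place: 2-fluorophenyl in place of 3-bromophenyl on a double-bonded chain carbon bound to an aromatic carbon. For the measured compounds named here, no measured step bears on this change, since the only step concerns the halogen alone and keeps its position, whereas here both the halogen and its position on the ring change. Compound 3 shows that the aryl groups are not interchangeable without loss, so the step is expected to be a 2.3-fold higher number from compound 2 to compound 4 (0.36 log units; beyond the scatter), most likely towards a higher number. Compound 4 is therefore estimated at 2500 nM, with a range from 800 nM to 8000 nM.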

Compound 4, half-maximal inhibitory concentration: 5500 nM
Compound 4: middle estimate off by 2.2-fold (0.34 log units), on the low side; the range from low to high includes it.
By their numbers in this assay, from the lowest: compounds 2 and 1 (each within the scatter of the next); then compound 4.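

In this assay, the aryl group on this double-bonded chain carbon turns out not to be indifferent to every exchange: a 5.0-fold higher number from compound 2 to compound 4 (0.70 log units; beyond the scatter) for 2-fluorophenyl in place of 3-bromophenyl, a change beyond the scatter, whereas the earlier exchange of bromo for chloro gave no change beyond it. The same holds when the step is read from the chloro member, with a 4.6-fold higher number from compound 1 to compound 4 (0.66 log units; beyond the scatter) for 2-fluorophenyl in place of 3-chlorophenyl, so both halogen-bearing groups of the earlier pair stand apart from 2-fluorophenyl by a modest margin. No measurement shown here gives a reason for this loss, and the step is recorded only as an observed difference in the read-out.

These steps change the halogen and its place on the ring together, so the compounds shown leave open which of the two carries the difference, a question that 3-fluorophenyl or 2-bromophenyl at this carbon would bear on directly. They also leave open how an unsubstituted phenyl or a 3-aminophenyl group would read at the same carbon.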